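Series notes: compound 3 to compound 4, aryl exchange

The compounds below may be only part of what the source reports. "The series", "measured", "known", "first", "only" and "open" are said of these compounds alone.

Measured so far in a functional assay on HT-29 cells (Homo sapiens) for inhibition, read by MTT assay, with a stated time of 48 h; on this read-out higher numbers stand for weaker inhibition and lower numbers for stronger inhibition:
compound 1 `COc1cc(/C=C/c2ccc(NC(=O)/C=C/c3ccc(C(F)(F)F)cc3)cc2)cc(OC)c1`, compound 1 gives 1780 nM
compound 2 `COc1cc(/C=C/c2ccc(NC(=O)/C=C/c3ccc([N+](=O)[O-])cc3)cc2)cc(OC)c1`, compound 2 gives 10700 nM
compound 3 `COc1cc(/C=C/c2ccc(NC(=O)/C=C/c3ccccc3F)cc2)cc(OC)c1`, compound 3 gives 2820 nM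

Compound 3 holds the second highest of the three numbers: to compound 1 the gap is a 1.6-fold higher number from compound 1 to compound 3 (0.20 log units; within the scatter), while a 3.8-fold lower number from compound 2 to compound 3 (0.58 log units; beyond the scatter) separates it from compound 2. Compound 4 `COc1cc(/C=C/c2ccc(NC(=O)/C=C/c3ccc(Cl)cc3)cc2)cc(OC)c1` is not yet measured; it differs from compound 3 by 4-chlorophenyl in place of 2-fluorophenyl on a double-bonded chain carbon bound to a double-bonded chain carbon. The measured aryl exchanges at this position span a 1.6-fold higher number from compound 1 to compound 3 (0.20 log units; within the scatter) and a 3.8-fold lower number from compound 2 to compound 3 (0.58 log units; beyond the scatter), and the change a 6.0-fold higher number from compound 1 to compound 2 (0.78 log units; beyond the scatter) shows how much a single substituent at this position can move the number. Going by the values given here, no step involving a 4-chlorophenyl has been measured, so the expectation rests only on these. For compound 4 a step of a 1.4-fold lower number from compound 3 to compound 4 (0.15 log units; within the scatter) is expected, within the scatter, giving an estimated 2000 nM in this assay, range 800 nM to 5000 nM.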

Compound 4, half-maximal inhibitory concentration: 10300 nM
Estimate against measurement, compound 4: 5.2-fold (0.71 log units) below; measured number above the stated range.
By their numbers in this assay, from the lowest: compounds 1 and 3 (each within the scatter of the next); then compounds 4 and 2 (each within the scatter of the next).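

In this cell read-out (this assay) 4-chlorophenyl does not behave like 2-fluorophenyl (a 3.7-fold higher number from compound 3 to compound 4 (0.56 log units; beyond the scatter)) or like 4-(trifluoromethyl)phenyl (a 5.8-fold higher number from compound 1 to compound 4 (0.76 log units; beyond the scatter)), whereas chloro in place of nitro on the aromatic carbon leaves the number within the scatter (a 1.0-fold lower number from compound 2 to compound 4 (0.02 log units; within the scatter)). The four aryl groups therefore fall into two pairs, compounds 1 and 3 against compounds 2 and 4, so a single substituent exchange here can move the number or leave it unchanged. Nothing at hand explains this split.

As far as these compounds go, whether an amine or a carboxylic acid on that aromatic carbon would fall with either pair remains open.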